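A few compounds are considered here, and "the series" means these few. Any claim that something is new, unique, unknown or untested is made for them only; others in the source may bear on it.

Measured in a functional assay on the whole organism with Mus musculus as the target; a higher number here means that more compound is needed for the effect, a lower number that less compound is needed:

Compound 1 `Cc1c(C)c2c(c(C)c1N)CC(C)(CN1CCC(c3ccccc3)CC1)O2`: 10.4 mg/kg
Compound 2 `Cc1c(C)c2c(c(C)c1N)CC(C)(CNCCCCc1ccccc1)O2`: 17 mg/kg
Compound 3 `Cc1c(C)c2c(c(C)c1NC=O)CC(C)(C)O2`: > 100 mg/kg

Compound 3 stands at the limit of > 100 mg/kg in this assay, at which 1 of the 3 values shown sits, so its entry is a limit and not a number.

Compound 4 `CCNc1c(C)c(C)c2c(c1C)CC(C)(C)O2` has ethyl in place of formyl on a nitrogen on an aromatic ring. Going by the values given here, no pair of measured compounds differs in one place, so no measured step can serve as a guide. The only clue is indirect. Compound 1 gives 10.4 mg/kg and compound 2 gives 17 mg/kg, and neither carries formyl on that nitrogen. Both also have a long side chain that compound 3 and compound 4 lack, so this clue is weak.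

On this basis, a move in this assay toward a lower number is expected, with a size beyond the usual scatter. The expected change is an at least 2.5-fold lower number from compound 3 to compound 4 (0.39 log units; beyond the scatter). Compound 4 may also fail to give a number and return only a limit. For compound 4 the estimated value is 40 mg/kg, with an expected range from 12 mg/kg to 130 mg/kg.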

Compound 4, dose for 50% inhibition: 38.9 mg/kg
Compound 4: the middle estimate sits 1.0-fold (0.01 log units) above what was measured, and the stated range covers the measured number.
By their numbers in this assay, from the lowest: compounds 1 and 2 (each within the scatter of the next); then compound 4. At a limit, above all of these: compound 3.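

Going by these compounds alone, on a nitrogen on an aromatic ring, the swap of formyl for ethyl is the first change in this set that can be read in one place, and in this assay it gives an at least 2.5-fold lower number from compound 3 to compound 4 (0.41 log units; beyond the scatter). The entry for compound 3 is a limit and not a number, so the step has a floor but no known full size: the limit of > 100 mg/kg in this assay, at which 1 of the 4 values shown sits. The two groups have the same number of heavy atoms, yet formyl brings an oxygen, a double bond and a hydrogen-bond acceptor that ethyl lacks, so this position responds to a change in the kind of group and not in its heavy-atom count, though one step cannot tell which of these differences matters.

As far as these compounds go, whether a bare amino group, an acetyl group or a longer chain such as butyl on this nitrogen would move the number further, in either direction, remains open. Also open, from the compounds shown here alone, is whether ethyl in place of the bare amino group would have any effect on the cores of compound 1 and compound 2, which carry long side chains.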